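Pyrimidine in Place of a Phenol on a Shared Core

This account rests on a few compounds, and the source may have more. Where it says the series, first, only, none or still open, it means among the compounds named here.

Compound 1 `COC(=O)c1ccccc1-c1cnc(C(=O)CCCCCCc2ccccc2)o1` gives 60 nM in an assay (Rattus norvegicus) for inhibition of Fatty-acid amide hydrolase 1 (Homo sapiens); a lower number here means a stronger inhibitor, a higher number a weaker inhibitor.
Compound 2 `O=C(CCCCCCc1ccccc1)c1ncc(-c2cccc(O)c2)o1` gives 50 nM in this assay.
Compound 3 `Nc1ccc(-c2cnc(C(=O)CCCCCCc3ccccc3)o2)cc1` gives 90 nM in this assay.

Compound 2 holds the lowest of the three numbers in this assay, but compound 1 and compound 3 sit within the scatter of it, so no order among the three can be claimed. Among the measured compounds shown here, the one measured step that exchanges the aryl group on the shared core, a 1.8-fold higher number from compound 2 to compound 3 (0.26 log units; within the scatter), stayed within the scatter, and the numbers of compound 1 and compound 2 show the same picture for a third aryl group.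

Compound 4 `O=C(CCCCCCc1ccccc1)c1ncc(-c2ccncn2)o1` is not yet measured. Compared with compound 2 it carries pyrimidin-4-yl in place of 3-hydroxyphenyl on an aromatic carbon. For the measured compounds named here, the single relevant step, from compound 2 to compound 3, was small, and the three aryl groups already seen all give numbers close to one another, so no change beyond the scatter is expected for compound 4 in this assay. Compound 4 is estimated to give 80 nM, with a range from 30 nM to 250 nM. This estimate means a step of a 1.6-fold higher number from compound 2 to compound 4 (0.20 log units; within the scatter), which is expected to lie within the scatter.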

Compound 4, inhibition constant: 2.3 nM
The estimate for compound 4 lay 35-fold (1.54 log units) above the measured number; the whole stated range lies above it.
By their numbers in this assay, from the lowest: compound 4; then compounds 2, 1 and 3 (each within the scatter of the next).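

Among the compounds shown here, at the aromatic carbon next to the ring oxygen of the shared core, the aryl group can matter far more in this assay than the earlier compounds suggested: the one earlier step (a 1.8-fold higher number from compound 2 to compound 3 (0.26 log units; within the scatter)) stayed within the scatter, while pyrimidin-4-yl in place of 3-hydroxyphenyl gives a large step (a 22-fold lower number from compound 2 to compound 4 (1.34 log units; beyond the scatter)), and pyrimidin-4-yl in place of 4-aminophenyl gives one larger still in number (a 39-fold lower number from compound 3 to compound 4 (1.59 log units; beyond the scatter)). Among the compounds shown, the aryl rings of carbon only, in compounds 1, 2 and 3, all sit close together, and only compound 4, with a six-membered aromatic ring with 2 hetero atoms, stands apart. Nothing measured here bears on why this exchange has so large an effect.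

The compounds shown leave open whether the result depends on having both ring nitrogens in this arrangement, which a pyridin-2-yl, pyrimidin-5-yl or pyrazin-2-yl group at the same carbon would test. They also leave open how far the result carries to other parts of the molecule, such as a pyrimidin-4-yl compound with a shorter chain in place of the phenyl-ended one, or with a carboxylic acid or an amine on the pyrimidine ring.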